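Methyl in Place of Iodo: Compound 3 to Compound 4

This account rests on a few compounds, and the source may have more. Where it says the series, first, only, none or still open, it means among the compounds named here.

Of the compounds shown here, three of the shared core have been measured in a functional assay on CHO cells for antagonist activity at Orexin/Hypocretin receptor type 1 (Homo sapiens), read by FLIPR and calcium flux; a higher number here means a weaker inhibitor, a lower number a stronger inhibitor. Compound 1 `C=Cc1nc(CC)n2c1C(CCc1ccc(C(F)(F)F)cc1)N([C@@H](C(=O)NC)c1ccccc1)CC2` gives 150 nM, compound 2 `CCOc1nc(CC)n2c1C(CCc1ccc(C(F)(F)F)cc1)N([C@@H](C(=O)NC)c1ccccc1)CC2` gives 3980 nM, and compound 3 `CCc1nc(I)c2n1CCN([C@@H](C(=O)NC)c1ccccc1)C2CCc1ccc(C(F)(F)F)cc1` gives 717 nM. Compound 3 thus stands second highest of the three, closer to compound 1 than to compound 2: a 4.8-fold higher number from compound 1 to compound 3 (0.68 log units; beyond the scatter), while a 5.6-fold lower number from compound 2 to compound 3 (0.74 log units; beyond the scatter). Between the two ends, a 27-fold higher number from compound 1 to compound 2 (1.42 log units; beyond the scatter).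

Compound 4 `CCc1nc(C)c2n1CCN([C@@H](C(=O)NC)c1ccccc1)C2CCc1ccc(C(F)(F)F)cc1` differs from compound 3 by methyl in place of iodo on an aromatic carbon. Within the data shown here, no measured step exchanges iodo for methyl, so the three known steps bear on it only indirectly: they show that the group on this aromatic carbon shifts the read-out modestly to largely, with vinyl giving the lowest number and ethoxy the highest. Since the exchange keeps one heavy atom in place of one heavy atom, a modest step at most is expected in this assay, more likely toward a lower number, in the direction of compound 1. For compound 4 the expected value is 300 nM, with a range from 100 nM to 1000 nM. The estimated step is a 2.4-fold lower number from compound 3 to compound 4 (0.38 log units; beyond the scatter).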

Compound 4, half-maximal inhibitory concentration: 10000 nM
The estimate for compound 4 lay 33-fold (1.52 log units) below the measured number; measured number above the stated range.
By their numbers in this assay, from the lowest: compound 1; then compound 3; then compound 2; then compound 4.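

In this assay, exchanging one heavy atom for one heavy atom on this aromatic carbon proves no small change: the numbers show a 14-fold higher number from compound 3 to compound 4 (1.14 log units; beyond the scatter) and a 2.5-fold higher number from compound 2 to compound 4 (0.40 log units; beyond the scatter) and a 67-fold higher number from compound 1 to compound 4 (1.82 log units; beyond the scatter) in turn. Compound 4 is therefore the weakest inhibitor of the four, so methyl rather than ethoxy now marks the top of the range at this position, and iodo and methyl, equal in heavy-atom count, stand a large step apart. No measurement at hand accounts for this step.

Open, as far as these compounds go, is whether an amine, a nitrile or a longer chain on this carbon would fall nearer to vinyl or to methyl. Also open, from the compounds shown here alone, is whether the order of these four groups holds when the ethyl group on the same ring changes.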